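Moving the Methoxy Group to Another Ring Carbon

The source may report more compounds than this note shows. Statements on the series, on what has been measured and on what is new or still open speak of the compounds shown alone.

The measured compounds:
compound 1, `CC(C)(C)OC(=O)/C=C1/C(=O)Nc2ccccc21`, gives 78.1% in a functional assay on SW480 cells (Homo sapiens) for inhibition, read by CCK-8 assay, with a stated time of 72 h, tested at 20 uM; a higher number here means more inhibition of growth at the concentration tested, a lower number less inhibition of growth
compound 2, `CC(C)c1ccc2c(c1)/C(=C\C(=O)OC(C)(C)C)C(=O)N2`, gives 78.5% in this assay
compound 3, `COc1ccc2c(c1)NC(=O)/C2=C/C(=O)OC(C)(C)C`, gives 78.8% in this assay

Compound 1 carries the unsubstituted shared core. Compound 2 and compound 3 each add one group to an aromatic carbon, and both steps stay inside the usual scatter: a number 0.4 percentage points higher from compound 1 to compound 2 (within the scatter) and a number 0.7 percentage points higher from compound 1 to compound 3 (within the scatter). On the numbers shown, the three compounds cannot be told apart, and no compound can be called the strongest or weakest among them.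

Compound 4, `COc1cccc2c1NC(=O)/C2=C/C(=O)OC(C)(C)C`, differs from compound 1 by methoxy in place of hydrogen on an aromatic carbon. For the measured compounds named here, the step from compound 1 to compound 3 is the closest precedent, as it also introduces a methoxy group on an aromatic carbon of the same core, though on a different carbon; the step from compound 1 to compound 2 adds a different group and is a weaker guide. Both of those steps remained within the scatter. A step beyond the scatter is therefore not expected, and the expected step is a number 0.9 percentage points higher from compound 1 to compound 4 (within the scatter). Compound 4 is estimated to give 79% in this assay, with a likely range from 68% to 89%.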

Compound 4, percent growth inhibition at one concentration: 77.8%
Compound 4: the middle estimate sits 1.2 percentage points above what was measured; the range from low to high includes it.
By their numbers in this assay, from the lowest: compounds 4, 1, 2 and 3 (each within the scatter of the next).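

With the methoxy group on this carbon, ortho to a fused ring and meta to a fused ring, the change gives a number 0.3 percentage points lower from compound 1 to compound 4 (within the scatter) in this assay, so a second aromatic carbon of the shared core now carries a methoxy group without a step beyond the scatter. For the compounds shown here, the location of the methoxy group therefore makes no difference that can be read from these two compounds: in this assay, compound 3 gives 78.8% and compound 4 gives 77.8%, and the earlier compounds, with only one methoxy location among them, could not show this. No measurement at hand offers any explanation for this flat result.

Going by these compounds, whether this carbon tolerates every kind of group remains open, since an amine, a carboxylic acid or a longer chain such as butoxy in its place might still produce a step beyond the scatter. The readings also come from a single test concentration, so the compounds shown leave open whether compound 1, compound 3 and compound 4 would separate under conditions where growth inhibition is less complete.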